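Phenyl for Isopropyl on Two Related Cores

The source may hold more compounds than are shown below. What is called first, only, known or untested is meant among the compounds shown, and "the series" means these compounds.

Measured in a functional assay on LoVo cells (Homo sapiens) for antiproliferative activity, read by MTT assay, with a stated time of 72 h; a lower number here means a stronger inhibitor of growth, a higher number a weaker inhibitor of growth:
Compound 1 `CC(=O)Nc1cc(OCC(C)C)nc(SCc2ccccc2)n1` gives 53900 nM.
Compound 2 `CC(=O)Nc1cc(OCc2ccccc2)nc(SCc2ccccc2)n1` gives 40000 nM.
Compound 3 `CC(C)Cn1c(SCc2ccccc2)nc(N)cc1=O` gives 68000 nM.

All three numbers are high and lie within the scatter of one another, so none of the three can be called stronger or weaker than the others. For the measured compounds named here, the one step that can be counted is a 1.3-fold lower number from compound 1 to compound 2 (0.13 log units; within the scatter), the change being (phenyl in place of isopropyl on a saturated chain carbon bound to an oxygen on an aromatic ring). Compound 3 rests on a different core from compound 1, and the difference between the two cores is not broken down here.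

Compound 4 `Nc1cc(=O)n(Cc2ccccc2)c(SCc2ccccc2)n1` is not yet measured. It differs from compound 3 by phenyl in place of isopropyl on a saturated chain carbon bound to an aromatic nitrogen. This is the same kind of change as that from compound 1 to compound 2, but not the same: there the phenyl replaced the isopropyl on a saturated chain carbon bound to an oxygen on an aromatic ring, here on a saturated chain carbon bound to an aromatic nitrogen. Because the earlier step was a 1.3-fold lower number from compound 1 to compound 2 (0.13 log units; within the scatter), a step of about a 1.4-fold lower number from compound 3 to compound 4 (0.13 log units; within the scatter) is expected in this assay. Compound 4 is therefore estimated at 50000 nM, with a likely range from 20000 nM to 130000 nM.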

Compound 4, concentration for 50% growth inhibition: 84900 nM
For compound 4 the middle estimate is 1.7-fold (0.23 log units) below the measured one, and the stated range covers the measured number.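

In this assay, phenyl in place of isopropyl on a saturated chain carbon bound to an aromatic nitrogen gives a 1.2-fold higher number from compound 3 to compound 4 (0.10 log units; within the scatter), a step too small to count as a change in either direction. Set beside the same kind of change on the other core, this step cannot be told apart from the earlier one: the same change on two cores in this assay, a 1.3-fold lower number (0.13 log units; within the scatter) from compound 1 to compound 2 and a 1.2-fold higher number (0.10 log units; within the scatter) from compound 3 to compound 4, 1.7-fold (0.23 log units) apart, within the scatter of two such steps. This shows that on both cores the change leaves the number within the scatter, but it does not show that a real effect would carry from one core to the other, as neither step is distinguishable from no effect and the chain is attached through an oxygen in one case and an aromatic nitrogen in the other.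

The compounds shown leave open whether any group at this place can move the number beyond the scatter, for example an amine, a carboxylic acid or a longer chain. As far as these compounds go, all four numbers are high, so it also remains open how this change would behave in a compound that inhibits growth more strongly.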